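Chlorobenzylsulfanyl Triazole Imide: Cytotoxicity Still Unmeasured

The source may hold more compounds than are shown below. What is called first, only, known or untested is meant among the compounds shown, and "the series" means these compounds.

Compound 1 `Cc1nnc(SCc2ccccc2Cl)n1N1C(=O)c2ccccc2C1=O`: > 200000 nM, a limit.
Compound 2 `C=CCSc1nnc(CCC)n1N1C(=O)c2ccccc2C1=O`: > 200000 nM, a limit.
Compound 3 `C#CCSc1nnc(CCC)n1N1C(=O)c2ccccc2C1=O`: > 200000 nM, a limit.

In a functional assay on A549 cells (Homo sapiens) for cytotoxicity, read by MTT assay, with a stated time of 48 h (on this read-out lower numbers stand for stronger inhibition and higher numbers for weaker inhibition), compound 3 stands only at a limit, shared with the other two values (the limit of > 200000 nM in this assay, at which 3 of the 3 values shown sit). Going by the values given here, the single measured step, a step that the two limits leave unreadable from compound 2 to compound 3, is unreadable between two limits. Compound 4 `CCCc1nnc(SCc2ccccc2Cl)n1N1C(=O)c2ccccc2C1=O` differs from compound 3 by 2-chlorophenyl in place of ethynyl on a saturated chain carbon bound to a sulfur. The same 2-chlorobenzyl group bound to sulfur already appears in compound 1, whose value is also a limit, so nothing measured points to a step beyond the scatter. The expected step of a number no higher from compound 3 to compound 4 (the limit leaves the size open) is therefore none that can be read. Compound 4 is estimated at 200000 nM, between 60000 nM and 400000 nM, most likely reported again as a limit.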

Compound 4, half-maximal inhibitory concentration: > 200000 nM
Compound 4 was reported as a limit (the forecaster's own chance of this, stated with the estimate: 80%); the middle value sits exactly at the limit.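

Going by these compounds alone, no step to compound 4 can be read from compound 1, compound 2 or compound 3, since all four values are limits: the limit of > 200000 nM in this assay, at which 4 of the 4 values shown sit. The compounds shown leave open how strongly any of them acts on these cells, and whether the group on sulfur matters at all.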